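Chloroalkyl Acyl Groups and Antiproliferative Potency: One Step Further

The compounds below may be only part of what the source reports. "The series", "measured", "known", "first", "only" and "open" are said of these compounds alone.

Compound 1 `COc1ccccc1C(=O)Nc1nnc(SCC(=O)Nc2ccc(Br)cn2)s1` in a functional assay on A875 cells (Homo sapiens) for antiproliferative activity, read by MTT assay, with a stated time of 48 h (on this read-out higher numbers stand for weaker inhibition and lower numbers for stronger inhibition), gives > 80000 nM, which is a limit of the assay and not a number.
Compound 2 `O=C(CSc1nnc(NC(=O)CCl)s1)Nc1ccc(Br)cn1` gives 13900 nM.
Compound 3 `O=C(CSc1nnc(NC(=O)C(Cl)Cl)s1)Nc1ccc(Br)cn1` gives 6500 nM.

Among the numbers actually measured, compound 3 stands lowest; its nearest neighbour is compound 2, and the step of a 2.1-fold lower number from compound 2 to compound 3 (0.33 log units; beyond the scatter) lies beyond the scatter. Compound 1 sits at the limit of > 80000 nM in this assay, at which 1 of the 3 values shown sits, so the steps of an at least 5.7-fold lower number from compound 1 to compound 2 (0.76 log units; beyond the scatter) and an at least 12-fold lower number from compound 1 to compound 3 (1.09 log units; beyond the scatter) can only be given as minimum sizes.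

Compound 4 `O=C(CSc1nnc(NC(=O)CCCl)s1)Nc1ccc(Br)cn1` carries the change (2-chloroethyl in place of dichloromethyl on a carbonyl carbon). Among the measured compounds shown here, no measured step directly covers a longer chloroalkyl chain. The closest evidence is a 2.1-fold lower number from compound 2 to compound 3 (0.33 log units; beyond the scatter), where a second chlorine on the same carbon lowered the number; compound 4 again holds a single chlorine, now one carbon further from the carbonyl, so it resembles compound 2 more than compound 3 in that respect. A modest rise in the number relative to compound 3 is therefore expected, roughly back toward compound 2, as a 2.3-fold higher number from compound 3 to compound 4 (0.36 log units; beyond the scatter). For compound 4 the estimated value in this assay is 15000 nM, within a range from 5000 nM to 50000 nM.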

Compound 4, half-maximal inhibitory concentration: 430 nM
The estimate for compound 4 lay 35-fold (1.54 log units) above the measured number, outside the stated range (below it).
By their numbers in this assay, from the lowest: compound 4; then compound 3; then compound 2. At a limit, above all of these: compound 1.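

At this position, on a carbonyl carbon whose other neighbour is an amide-type nitrogen, the 2-chloroethyl group far outdoes both chlorinated groups with a single carbon in this assay, with a 15-fold lower number from compound 3 to compound 4 (1.18 log units; beyond the scatter) and a 32-fold lower number from compound 2 to compound 4 (1.51 log units; beyond the scatter). The earlier compounds had shown only a small gain from adding a chlorine, a 2.1-fold lower number from compound 2 to compound 3 (0.33 log units; beyond the scatter), so counting chlorines does not explain the order: compound 4 goes against that trend, holding one chlorine fewer than compound 3 yet giving the lowest number of the series. Compound 1 gives a limit of the assay and not a number, so an at least 180-fold lower number from compound 1 to compound 4 (2.26 log units; beyond the scatter) is a minimum size only: the limit of > 80000 nM in this assay, at which 1 of the 4 values shown sits.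

The compounds shown leave open whether the gain continues with a longer chain such as 3-chloropropyl, and whether the chlorine matters at all, which a plain ethyl or a 2-bromoethyl group on the same carbonyl would help to settle. They also give no cause for so large a change from such a small structural difference, and they cover only this one cell line.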